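The source may report more compounds than this note shows. Statements on the series, on what has been measured and on what is new or still open speak of the compounds shown alone.

Of the compounds shown here, three built on one shared core have been tested in a functional assay on PC-3 cells (Homo sapiens) for inhibition, read by MTT assay, with a stated time of 48 h, tested at 10 uM; a lower number here means less inhibition of growth, a higher number more inhibition of growth at the concentration tested. There, compound 1 `COc1ccc(COc2cc(O)c3c(=O)cc(C)oc3c2[C@H]2CCN(C)C[C@H]2O)cc1` gives 35%, compound 3 `Cc1cc(=O)c2c(O)cc(OCc3ccccc3Br)c([C@H]3CCN(C)C[C@H]3O)c2o1` gives 32% and compound 2 `Cc1cc(=O)c2c(O)cc(OCc3ccc([N+](=O)[O-])cc3)c([C@H]3CCN(C)C[C@H]3O)c2o1` gives 23%. Compound 2 thus has the lowest of the three numbers, although only its gap to compound 1 is a real one: the data show a number 12 percentage points lower from compound 1 to compound 2 (beyond the scatter), but also a number 9 percentage points higher from compound 2 to compound 3 (within the scatter).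

Compound 4 `Cc1cc(=O)c2c(O)cc(OC/C=C/c3ccccc3)c([C@H]3CCN(C)C[C@H]3O)c2o1` has not yet been measured. It differs from compound 2 as follows: 2-phenylethenyl in place of 4-nitrophenyl on a saturated chain carbon bound to an oxygen on an aromatic ring. Among the measured compounds shown here, the same change reads 4-nitrobenzyl to 3-phenylprop-2-en-1-yl, and no measured compound carries the new group. The two steps that bear on it both concern the 4-nitrophenyl group, and they are small to modest. Compound 4 is therefore expected to fall near compound 1 and compound 3, with a gain that is modest at best. The expected change is a number 7 percentage points higher from compound 2 to compound 4 (within the scatter). The estimated value for compound 4 is 30%, within an expected range of 17% to 43%.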

Compound 4, percent growth inhibition at one concentration: 18%
Beside the measured number, compound 4's estimate is 12 percentage points above it, and the stated range covers the measured number.
By their numbers in this assay, from the lowest: compounds 4, 2, 3 and 1 (each within the scatter of the next, the first and the last beyond it).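

In this assay, 2-phenylethenyl and 4-nitrophenyl on the saturated chain carbon bound to an oxygen on an aromatic ring are not told apart, with a number 5 percentage points lower from compound 2 to compound 4 (within the scatter), while the same entering group gives a number 14 percentage points lower from compound 3 to compound 4 (beyond the scatter) and a number 17 percentage points lower from compound 1 to compound 4 (beyond the scatter). Compound 4 therefore lies beyond the scatter of both compound 1 and compound 3, whereas compound 2 did so only for compound 1, so a change at this place can also separate a compound from the 2-bromophenyl one. Nothing available explains these differences.

On these data alone, whether an unsubstituted benzyl group would differ from these groups remains open, as does the effect of an amine or a carboxylic acid on its phenyl ring. A saturated chain in place of the 3-phenylprop-2-en-1-yl group is equally untested among the compounds shown.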